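A few compounds are considered here, and "the series" means these few. Any claim that something is new, unique, unknown or untested is made for them only; others in the source may bear on it.

For the measured compounds named here, compound 2 `Cc1cccc(COc2ccc(-c3nn(CCC#N)c(=S)o3)cc2)c1` gives the lowest of the two numbers so far in an assay for inhibition of Amine oxidase [flavin-containing] B (Rattus norvegicus); a higher number here means a weaker inhibitor, a lower number a stronger inhibitor: compound 2 gives 66 nM, while compound 1 `COc1ccc(COc2ccc(-c3nn(CCC#N)c(=S)o3)cc2)cc1` gives 910 nM. Compound 3 `N#CCCn1nc(-c2ccc(OCc3ccc([N+](=O)[O-])cc3)cc2)oc1=S` differs from compound 2 by 4-nitrophenyl in place of 3-methylphenyl on a saturated chain carbon bound to an oxygen on an aromatic ring. Going by the values given here, the only step that bears on this change is the exchange of a 4-methoxyphenyl for a 3-methylphenyl, a 14-fold lower number from compound 1 to compound 2 (1.14 log units; beyond the scatter), which runs in the opposite sense to the present change. Compound 3 is therefore expected to give a higher number in this assay, a step estimated as a 6.1-fold higher number from compound 2 to compound 3 (0.78 log units; beyond the scatter). Compound 3 is estimated at 400 nM, within a range of 100 nM to 1600 nM.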

Compound 3, half-maximal inhibitory concentration: 4300 nM
The estimate for compound 3 lay 11-fold (1.03 log units) below the measured number; the whole stated range lies below it.
By their numbers in this assay, from the lowest: compound 2; then compound 1; then compound 3.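

At this place, on a saturated chain carbon bound to an oxygen on an aromatic ring, 4-nitrophenyl in place of 3-methylphenyl gives a 65-fold higher number from compound 2 to compound 3 (1.81 log units; beyond the scatter) in this assay, a larger step than the earlier exchange. Nitro in place of methoxy on an aromatic carbon gives a 4.7-fold higher number from compound 1 to compound 3 (0.67 log units; beyond the scatter), so the two 4-substituted phenyl groups also differ beyond the scatter. No measurement shown explains the size of these steps.

From the compounds shown here alone, whether the low number of compound 2 follows from the methyl group or its ring position remains open; 4-methylphenyl or 3-nitrophenyl could separate the two.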